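A few compounds are considered here, and "the series" means these few. Any claim that something is new, unique, unknown or untested is made for them only; others in the source may bear on it.

Measured in an assay on CHO cells for displacement of a labelled ligand from adenosine receptor A3 (Homo sapiens), read by scintillation counting, with a stated time of 120 min, tested at 1 uM; a lower number here means less inhibition, a higher number more inhibition at the concentration tested (going by the name of the read-out):
- compound 1 `CCOc1ccc(-c2c(C#N)c(N)nc(SCc3ccn[nH]3)c2C#N)cc1` gives 18%
- compound 2 `N#Cc1c(N)nc(SCc2ccn[nH]2)c(C#N)c1-c1ccc(OCC2CC2)cc1` gives 6%
- compound 3 `CC(C)COc1ccc(-c2c(C#N)c(N)nc(SCC(N)=O)c2C#N)cc1` gives 9%

Compound 2 holds the lowest of the three numbers. Its gap to compound 3 lies within the scatter, so nothing separates the two. Among the measured compounds shown here, compound 1 stands higher: the step of a number 12 percentage points lower from compound 1 to compound 2 (beyond the scatter), cyclopropyl in place of methyl on a saturated chain carbon bound to an oxygen on an aromatic ring, is beyond the scatter and is the only measured step in the set.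

Compound 4 `N#Cc1c(N)nc(SCc2nc3ccccc3[nH]2)c(C#N)c1-c1ccc(OCC2CC2)cc1` keeps the cyclopropyl side of compound 2 and changes the other end: 1H-benzimidazol-2-yl in place of 1H-pyrazol-5-yl on a saturated chain carbon bound to a sulfur. For the measured compounds named here, no measured step touches the group on the saturated chain carbon bound to a sulfur. Compound 3 carries a different group there, but it also differs from compound 1 and compound 2 at the oxygen side, so its value cannot be read as a step for this position. Going by the values given here, all three values sit in the same low region, and the one step beyond the scatter runs elsewhere in the molecule.

In this assay no step beyond the scatter is therefore expected from compound 2 to compound 4, and the expected step is a number 4 percentage points higher from compound 2 to compound 4 (within the scatter). Compound 4 is estimated at 10%, with a range from 0% to 30%.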

Compound 4, a percentage reported as inhibition, at one concentration (the size of the read-out at that concentration, not a potency): 1%
Compound 4: the middle estimate sits 9 percentage points above what was measured, and the stated range covers the measured number.
By their numbers in this assay, from the lowest: compounds 4, 2, 3 and 1 (each within the scatter of the next, the first and the last beyond it).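

In this assay, the group on a saturated chain carbon bound to a sulfur now has its first direct reading, with the cyclopropyl side held constant: 1H-benzimidazol-2-yl in place of 1H-pyrazol-5-yl gives a number 5 percentage points lower from compound 2 to compound 4 (within the scatter). The change goes from 5 heavy atoms to 9 heavy atoms and adds a six-membered aromatic ring of carbon only, yet the two compounds cannot be separated in this read-out, a comparison that compound 3 could not provide as it also differs at the oxygen side. No supporting data bear on why the two groups read alike.

Still open, as far as these compounds go, is whether a different kind of group on this saturated chain carbon, such as an amine or a carboxylic acid, would give a step beyond the scatter with the cyclopropyl side kept. Also open, from the compounds shown here alone, is whether 1H-benzimidazol-2-yl would read the same way with the methyl side of compound 1, which gives the highest number of the set at 18%, where a fall would have more room to show.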